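A few compounds are considered here, and "the series" means these few. Any claim that something is new, unique, unknown or untested is made for them only; others in the source may bear on it.

Compound 1 `C/C=C1/[C@H](O[C@@H]2O[C@H](CO)[C@@H](O)[C@H](O)[C@H]2O)OC=C(C(=O)OC)[C@H]1CC(=O)OCCCc1ccc(OC)c(OC)c1`: in a functional assay on SK-BR-3 cells (Homo sapiens) for antiproliferative activity, read by MTT assay, with a stated time of 72 h (a higher number here means a weaker inhibitor, a lower number a stronger inhibitor), compound 1 reaches only the limit > 20000 nM.
Compound 2 `C/C=C1/[C@H](O[C@@H]2O[C@H](CO)[C@@H](O)[C@H](O)[C@H]2O)OC=C(C(=O)OC)[C@H]1CC(=O)OCCc1ccc(OC)cc1`: in this assay compound 2 likewise stops at the limit > 20000 nM.
Compound 3 `C=C(C)CCOC(=O)C[C@@H]1C(C(=O)OC)=CO[C@@H](O[C@@H]2O[C@H](CO)[C@@H](O)[C@H](O)[C@H]2O)/C1=C/C`: in this assay compound 3 stops at the limit > 15000 nM.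

All three compounds share the same core and differ only in the group on the ester chain. None of them gives a number; each result is a limit of the assay, as the limit of > 15000 nM in this assay, at which 1 of the 3 values shown sits, and the limit of > 20000 nM in this assay, at which 2 of the 3 values shown sit, record. The steps between them are therefore unreadable: a step that the two limits leave unreadable from compound 1 to compound 2, a step that the two limits leave unreadable from compound 1 to compound 3 and a step that the two limits leave unreadable from compound 2 to compound 3. Compound 3 thus sits at one of these limits, and nothing in the numbers sets it apart from the other two.

Compound 4 `C/C=C1/[C@H](O[C@@H]2O[C@H](CO)[C@@H](O)[C@H](O)[C@H]2O)OC=C(C(=O)OC)[C@H]1CC(=O)OCCC(C)C` differs from compound 3 in one place: isopropyl in place of 1-methylethenyl on a saturated chain carbon, two bonds along the chain from an oxygen next to a carbonyl group. Going by the values given here, no measured step bears on this change with a readable size; every step recorded here runs between two limits. No step beyond the scatter can be expected in this assay in either direction, and the most probable outcome is another limit. The expected result for compound 4 is 20000 nM, within 10000 nM to 60000 nM. The step this estimate implies is a step that the limit leaves unreadable from compound 3 to compound 4, expected to be flat.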

Compound 4, half-maximal inhibitory concentration: 9020 nM
For compound 4 the middle estimate is 2.2-fold (0.35 log units) above the measured one; measured number outside the range, below it.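

Among the four compounds, only compound 4 gives a true number in this assay: compound 4 reaches 9020 nM, so a measurable effect appears with isopropyl on this saturated chain carbon. Replacing either aromatic group with isopropyl gives an at least 2.2-fold lower number from compound 2 to compound 4 (0.34 log units; beyond the scatter) and an at least 2.2-fold lower number from compound 1 to compound 4 (0.34 log units; beyond the scatter), and each is a floor, which means the real step could be larger. The change from 1-methylethenyl to isopropyl keeps the same count of heavy atoms and removes only the double bond, and it gives an at least 1.6-fold lower number from compound 3 to compound 4 (0.22 log units; that floor lies within the scatter); with that floor inside the scatter, the data do not establish that removing the double bond matters.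

As far as these compounds go, the steps among compound 1, compound 2 and compound 3 still cannot be read, and the true size of every step to compound 4 remains unknown. Also open, from the compounds shown here alone, is how this position responds to other groups, such as a smaller ethyl group, a longer alkyl chain, or a chain ending in an amine or a carboxylic acid.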